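The compounds below may be only part of what the source reports. "The series", "measured", "known", "first", "only" and "open" are said of these compounds alone.

Measured compounds and their results in an ADME assay on RAW264.7 cells (Mus musculus) for cytotoxicity, read by MTT assay, with a stated time of 24 h, tested at 2.5 ug/mL; a lower number here means a stronger effect, a higher number a weaker effect of the compound at the concentration tested:

compound 1, `COc1cc(C(=O)/C=C/c2cccc(OC)c2OC)ccc1O`, 94%
compound 2, `COc1ccc(/C=C/C(=O)c2ccc(OC)c(OC)c2)cc1`, 93.1%
compound 3, `COc1cc(C(=O)CCc2cccc(OC)c2OC)ccc1O`, 94.5%

All three numbers sit high on the scale of this assay, and each lies within the usual scatter of the other two, so none of the three can be set apart as acting more or less strongly on the cells at this concentration. Compound 2 thus stands in the same band as compound 1 and compound 3, with nothing in the figures to tell it from either.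

The step followed here goes from compound 2 to compound 4, `COc1ccc(/C=C/C(=O)c2ccc(OC)c(OC)c2)cc1OC`, which has not yet been measured in this assay. The change counted between the two structures is methoxy in place of hydrogen on an aromatic carbon. Among the compounds with values here, no step between two measured compounds is given, so there is no pair in the data from which the size of such a change could be read. What the three measured compounds do show is that the numbers in this assay have so far stayed close together, whatever the change between them.

For compound 4 the expectation is a number of the same kind, with a step from compound 2 of a number 0.1 percentage points lower from compound 2 to compound 4 (within the scatter), which is no more than the scatter. Compound 4 is estimated at 93%, with a likely range from 84% to 99%.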

Compound 4, a percentage reported as activity, at one concentration (the size of the read-out at that concentration, not a potency): 91.9%
Compound 4: middle estimate off by 1.1 percentage points, on the high side; measured number inside the range.
By their numbers in this assay, from the lowest: compounds 4, 2, 1 and 3 (each within the scatter of the next).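

This is the only pair shown that differs in one place, so the size of a single change can now be read. With methoxy in place of hydrogen on an aromatic carbon, ortho to a methoxy group and meta to a large group, the result in this assay is a number 1.2 percentage points lower from compound 2 to compound 4 (within the scatter). At this position, the added methoxy therefore leaves compound 4 indistinguishable from compound 2 at the concentration tested, and no available evidence bears on why.

From the compounds shown here alone, it remains open whether an amine, a carboxylic acid or a longer chain at this position would give a step beyond the scatter. Going by these compounds, the effect of methoxy on other aromatic carbons of the core also remains open.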